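Tetrazole series: chain ester in place of sulfonamide

The source may hold more compounds than are shown below. What is called first, only, known or untested is meant among the compounds shown, and "the series" means these compounds.

Three measured compounds share one core. In an assay on isolated protein for displacement of a labelled ligand from growth hormone secretagogue receptor type 1 (Homo sapiens), with a stated time of 1 h (on this read-out higher numbers stand for weaker inhibition and lower numbers for stronger inhibition), compound 1 `CC(C)(N)C(=O)N[C@H](COCc1ccccc1)c1nnnn1Cc1ccc(NS(C)(=O)=O)cc1` reaches only the limit > 5000 nM. Compound 2 `CC(C)(N)C(=O)N[C@H](COCc1ccccc1)c1nnnn1CCCCCNS(C)(=O)=O` likewise gives only the limit > 5000 nM in this assay. Compound 3 `CC(C)(N)C(=O)N[C@H](COCc1ccccc1)c1nnn(Cc2cccc(NS(C)(=O)=O)c2)n1` gives the limit > 5000 nM in this assay. Among the compounds with values here, compound 2 therefore stands nowhere above the others: all that is known is the limit of > 5000 nM in this assay, at which 3 of the 3 values shown sit, and the one single-point step, a step that the two limits leave unreadable from compound 1 to compound 2, cannot be read.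

Compound 4 `COC(=O)CCCn1nnnc1[C@@H](COCc1ccccc1)NC(=O)C(C)(C)N` has yet to be measured. Against compound 2 the change is methoxycarbonyl in place of 2-(methanesulfonamido)ethyl on a saturated chain carbon, three bonds along the chain from an aromatic nitrogen. Within the data shown here, no measured step bears on this change; the only neighbouring step, a step that the two limits leave unreadable from compound 1 to compound 2, is itself hidden by the limits. With every value at the limit, compound 4 is expected to sit near the limit as well, the step that the limit leaves unreadable from compound 2 to compound 4 being an expectation and not a measurement. The estimate for compound 4 in this assay is 8000 nM, within 2000 nM to 40000 nM.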

Compound 4, inhibition constant: 2380 nM
Compound 4: middle estimate off by 3.4-fold (0.53 log units), on the high side; measured number inside the range.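

In this assay, the chain position on the aromatic nitrogen now gives a real number rather than a limit: methoxycarbonyl in place of 2-(methanesulfonamido)ethyl on a saturated chain carbon, three bonds along the chain from an aromatic nitrogen, gives an at least 2.1-fold lower number from compound 2 to compound 4 (0.32 log units; beyond the scatter). Measured against the aryl group, 2-(methoxycarbonyl)ethyl in place of 4-(methanesulfonamido)phenyl gives an at least 2.1-fold lower number from compound 1 to compound 4 (0.32 log units; beyond the scatter). Both sizes are lower bounds, and compound 4 alone in the set shown comes off the limit: the limit of > 5000 nM in this assay, at which 3 of the 4 values shown sit.

The step from compound 1 to compound 2 still cannot be read. On these data alone, it also stays open whether the methoxycarbonyl group itself matters or only the loss of the methanesulfonamido group, a question that a carboxylic acid, an amine or a longer chain ending in methoxycarbonyl at this position could address.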